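The source may hold more compounds than are shown below. What is called first, only, known or untested is meant among the compounds shown, and "the series" means these compounds.

Compound 1 `FC(F)(F)Oc1ccc(-c2cc(COc3ccccc3-c3nc4ccccc4s3)on2)cc1`: 19900 nM
Compound 2 `Brc1ccc(-c2cc(COc3ccccc3-c3nc4ccccc4s3)on2)cc1`: 16400 nM
Compound 3 `FC(F)(F)C(F)(F)C(F)(F)C(F)(F)C(F)(F)C(F)(F)C(F)(F)C(F)(F)CCn1cc(COc2ccccc2-c2nc3ccccc3s2)nn1`: 12200 nM

All three numbers come from a functional assay on COLO 205 cells (Homo sapiens) for cytotoxicity, read by MTT assay, with a stated time of 24 h; a lower number here means a stronger inhibitor, a higher number a weaker inhibitor. For the measured compounds named here, the number for compound 2 lies between those of compound 1 and compound 3, and all three lie within the usual scatter of one another; the single step with a shared core, a 1.2-fold lower number from compound 1 to compound 2 (0.08 log units; within the scatter), did not move the number beyond that scatter.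

Compound 4 `Fc1ccccc1-c1cc(COc2ccccc2-c2nc3ccccc3s2)on1` has not yet been measured. It differs from compound 2 by 2-fluorophenyl in place of 4-bromophenyl on an aromatic carbon. Going by the values given here, no measured pair swaps these two groups, so the only guide is that the one change made so far on this ring left the number essentially unchanged. The expected step is therefore small, a 1.0-fold higher number from compound 2 to compound 4 (0.02 log units; within the scatter), in no clear direction. Compound 4 is estimated at 17000 nM, with a likely range from 7000 nM to 40000 nM.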

Compound 4, half-maximal inhibitory concentration: 18300 nM
For compound 4 the middle estimate is 1.1-fold (0.03 log units) below the measured one; low and high end bracket the measured number.
By their numbers in this assay, from the lowest: compounds 3, 2, 4 and 1 (each within the scatter of the next).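

Changing the aryl group on this aromatic carbon of the five-membered ring left the number in this assay essentially in place, both against the bromo compound (a 1.1-fold higher number from compound 2 to compound 4 (0.05 log units; within the scatter)) and against the trifluoromethoxy compound (a 1.1-fold lower number from compound 1 to compound 4 (0.04 log units; within the scatter)). Replacing 4-bromophenyl with 2-fluorophenyl changes both the halogen and where it sits on the phenyl ring, yet the step stays within the scatter. No evidence is available to explain this flat result. From the compounds shown here alone, whether an amine or a carboxylic acid on the phenyl ring would move the number remains open.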